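The source may report more compounds than this note shows. Statements on the series, on what has been measured and on what is new or still open speak of the compounds shown alone.

In a functional assay on MDA-MB-435 cells (Homo sapiens) for inhibition (a higher number here means a weaker inhibitor, a lower number a stronger inhibitor), compound 1 `COc1cc[nH]c1/C=C1\C(=O)Nc2ccc(F)c(I)c21` reaches only a limit, > 30000 nM. Among the compounds with values here, compound 2 `CCN[C@H](C#Cc1c(F)ccc2c1/C(=C/c1[nH]ccc1OC)C(=O)N2)[C@@H](C)O` gives 1070 nM, the only actual number so far. Swapping iodo for 3-(ethylamino)-4-hydroxypent-1-yn-1-yl produced an at least 28-fold lower number from compound 1 to compound 2 (1.44 log units; beyond the scatter). Compound 3 `COc1cc[nH]c1/C=C1\C(=O)Nc2ccc(F)c(C#C[C@@H]3CCCN3)c21` alters the end of that chain: pyrrolidin-2-yl in place of 1-(ethylamino)-2-hydroxypropyl on a triple-bonded carbon. Within the data shown here, that one large step is the only measured evidence, and it does not test this exchange, so it sets no firm direction. With the triple-bonded carbon kept, a small move towards a higher number is expected, a 1.4-fold higher number from compound 2 to compound 3 (0.15 log units; within the scatter). Compound 3 is estimated at 1500 nM, within an expected range of 400 nM to 6000 nM.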

Compound 3, half-maximal inhibitory concentration: 31 nM
For compound 3 the middle estimate is 48-fold (1.68 log units) above the measured one; measured number outside the range, below it.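

In this assay, the group on the triple-bonded carbon matters in its own right: pyrrolidin-2-yl in place of 1-(ethylamino)-2-hydroxypropyl gave a 35-fold lower number from compound 2 to compound 3 (1.54 log units; beyond the scatter). Replacing iodo with 2-(pyrrolidin-2-yl)ethynyl gave an at least 960-fold lower number from compound 1 to compound 3 (2.98 log units; beyond the scatter). The size of that second step has no upper bound, as compound 1 reaches only a limit: the limit of > 30000 nM in this assay, at which 1 of the 3 values shown sits.

This exchange introduces the ring and removes the hydroxy group together, leaving their separate contributions unresolved. Also open, going by these compounds, is how a piperidin-2-yl group or an open-chain amine without hydroxy would compare on the same carbon.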